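The source may report more compounds than this note shows. Statements on the series, on what has been measured and on what is new or still open speak of the compounds shown alone.

Compound 2, `COc1cccc(Cn2cc(-c3ccc4ccccc4c3)nn2)c1`, is the point of departure. In a functional assay on B16 cells (Mus musculus) for cytotoxicity, read by MTT assay, with a stated time of 48 h (on this read-out lower numbers stand for stronger inhibition and higher numbers for weaker inhibition), compound 2 gives > 100000 nM, which is a limit of the assay and not a number. Two further compounds were tested the same way. Compound 1, `CCOC(=O)Cn1cc(-c2ccc([N+](=O)[O-])cc2)nn1`, gives > 100000 nM in this assay, again a limit. Compound 3, `OC(c1ccc(C(F)(F)F)cc1)c1cn(Cc2ccccc2)nn1`, gives > 100000 nM in this assay, also a limit. All three results thus stand at the same place: the limit of > 100000 nM in this assay, at which 3 of the 3 values shown sit. Compound 2 stands with the others, and nothing in the numbers sets it apart from compound 1 or compound 3; none of the three can be called more or less active than another.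

Compound 4, `OCCCn1cc(-c2ccc3ccccc3c2)nn1`, has not yet been measured in this assay. It differs from compound 2 in one place: 2-hydroxyethyl in place of 3-methoxyphenyl on a saturated chain carbon bound to an aromatic nitrogen. For the measured compounds named here, no step between measured compounds is available for this change or any other, so there is no measured guide to its size or direction. Given that every compound so far sits at the limit, the change is expected to amount to a step that the limit leaves unreadable from compound 2 to compound 4, which is none beyond the scatter. Compound 4 is therefore estimated at 150000 nM in this assay, within 50000 nM to 500000 nM, with a limit rather than a number the most likely report.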

Compound 4, half-maximal inhibitory concentration: > 100000 nM
Compound 4: a limit, no number; the forecaster's own chance of this, stated with the estimate: 85%; the middle value is on the limit's open side.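

No step can be read from compound 2 to compound 4 in this assay since both results are limits and not numbers: the limit of > 100000 nM in this assay, at which 4 of the 4 values shown sit.

The compounds shown leave open how 2-hydroxyethyl in place of 3-methoxyphenyl alters the value, and what structural change, if any, would give a number rather than a limit.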